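Removing the methyl from compound 2: what to expect

The source may report more compounds than this note shows. Statements on the series, on what has been measured and on what is new or still open speak of the compounds shown alone.

Going by the values given here, compound 2 `COc1cc(-c2nn(-c3cccc(NC(=O)Nc4cc(C(F)(F)F)cc(C(F)(F)F)c4)c3)cc2-c2ccncc2)ccc1Cl` gives the lowest of the three numbers so far measured in a functional assay on NCI-H322M cells (Homo sapiens) for inhibition, read by sulforhodamine B assay, with a stated time of 48 h (a lower number here means a stronger inhibitor of growth, a higher number a weaker inhibitor of growth), with compound 2 at 1020 nM. Compound 3 `COc1cc(-c2nn(-c3cccc(NC(=O)Nc4cccc(C(F)(F)F)c4)c3)cc2-c2ccncc2)ccc1Cl` stands nearest, at 1210 nM, and the step of a 1.2-fold higher number from compound 2 to compound 3 (0.07 log units; within the scatter) lies within the scatter. Compound 1 `O=C(Nc1cccc(-n2cc(-c3ccncc3)c(-c3ccc(Cl)c(O)c3)n2)c1)Nc1cccc(C(F)(F)F)c1` stands furthest, at 6410 nM, and the step of a 5.3-fold lower number from compound 1 to compound 3 (0.72 log units; beyond the scatter) is beyond the scatter. Compound 4 `O=C(Nc1cccc(-n2cc(-c3ccncc3)c(-c3ccc(Cl)c(O)c3)n2)c1)Nc1cc(C(F)(F)F)cc(C(F)(F)F)c1` has not yet been measured; it differs from compound 2 by hydrogen in place of methyl on an oxygen on an aromatic ring, that is, methoxy to hydroxy, or 4-chloro-3-methoxyphenyl to 4-chloro-3-hydroxyphenyl. Among the compounds with values here, the only measured step that bears on this change is a 5.3-fold lower number from compound 1 to compound 3 (0.72 log units; beyond the scatter), which is the same change in the opposite direction; reversed, it points to a higher number in this assay of about that size, though it rests on one pair alone. Compound 4 is therefore expected to give 5400 nM, with a range from 2500 nM to 12000 nM. The expected step is a 5.3-fold higher number from compound 2 to compound 4 (0.72 log units; beyond the scatter).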

Compound 4, concentration for 50% growth inhibition: 1310 nM
Beside the measured number, compound 4's estimate is 4.1-fold (0.62 log units) above it; the measured number lies below the stated range.
By their numbers in this assay, from the lowest: compounds 2, 3 and 4 (each within the scatter of the next); then compound 1.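

In this assay, methoxy to hydroxy on the shared core gives a 1.3-fold higher number from compound 2 to compound 4 (0.11 log units; within the scatter), so the loss that the same change brought in the pair without the added trifluoromethyl does not carry over: the same change on two cores in this assay, a 5.3-fold lower number (0.72 log units; beyond the scatter) from compound 1 to compound 3 and a 1.3-fold lower number (0.11 log units; within the scatter) from compound 4 to compound 2, 4.1-fold (0.62 log units) apart, beyond the scatter of two such steps. Read the other way, trifluoromethyl in place of hydrogen on an aromatic carbon gives a 4.9-fold lower number from compound 1 to compound 4 (0.69 log units; beyond the scatter) where the hydroxy is present, yet stays within the scatter where the methoxy is present: the same change on two cores in this assay, a 1.2-fold higher number (0.07 log units; within the scatter) from compound 2 to compound 3 and a 4.9-fold higher number (0.69 log units; beyond the scatter) from compound 4 to compound 1, 4.1-fold (0.62 log units) apart, beyond the scatter of two such steps. The two changes therefore do not add up independently: compound 2, compound 3 and compound 4 stand within the scatter of each other, and only compound 1, with the hydroxy and without the added trifluoromethyl, stands apart.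

The compounds shown leave open whether a longer chain on that oxygen, such as ethyl, would fall with this group or with compound 1. They also leave open whether chlorine in place of the added trifluoromethyl, or an amine in place of the hydroxy, would behave the same way.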